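The compounds below may be only part of what the source reports. "The series", "measured", "known", "first", "only" and "open" are said of these compounds alone.

Working notes on the series. Compound 2 `O=C(O)/C=C/C(=O)Nc1cccc(-c2nc3ccccc3s2)c1` carries a 2-carboxyethenyl on a carbonyl carbon of the shared core. In an ADME assay on HepG2 cells (Homo sapiens) for inhibition, with a stated time of 72 h (a lower number here means that less compound is needed, a higher number that more compound is needed for the effect), compound 2 gives only a limit, > 25000 nM. Compound 1 `C=C(C)C(=O)Nc1cccc(-c2nc3ccccc3s2)c1` likewise reaches only a limit, > 25000 nM. Compound 3 `O=C(CCl)Nc1cccc(-c2nc3ccccc3s2)c1` gives 16000 nM. Hence a step that the two limits leave unreadable from compound 1 to compound 2, while an at least 1.5-fold lower number from compound 1 to compound 3 (0.19 log units; that floor lies within the scatter) and an at least 1.5-fold lower number from compound 2 to compound 3 (0.19 log units; that floor lies within the scatter) are floors that sit inside the scatter; two of the three values rest at the limit of > 25000 nM in this assay, at which 2 of the 3 values shown sit. Compound 4 `O=C(Nc1cccc(-c2nc3ccccc3s2)c1)c1ccnc(Cl)c1` differs from compound 2 by 2-chloropyridin-4-yl in place of 2-carboxyethenyl on a carbonyl carbon. Among the compounds with values here, no measured step covers an aromatic group at this position, and the only readable movement is the small floor toward compound 3. Compound 4 is therefore expected to stay near the limit, with a step that the limit leaves unreadable from compound 2 to compound 4 not beyond the scatter. The estimate for compound 4 is 30000 nM, range 8000 nM to 100000 nM.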

Compound 4, half-maximal effective concentration: > 25000 nM
Compound 4: no number, only a limit (the forecaster's own chance of this, stated with the estimate: 70%); the middle value does not contradict the limit.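

Within the data shown here, an aromatic ring on this carbonyl carbon joins the 1-methylethenyl and 2-carboxyethenyl groups at the same limit, so three different groups now rest there in this assay: the limit of > 25000 nM in this assay, at which 3 of the 4 values shown sit. The one readable comparison is an at least 1.5-fold higher number from compound 3 to compound 4 (0.19 log units; that floor lies within the scatter), which does not clearly set chloromethyl apart from 2-chloropyridin-4-yl. The steps among the compounds at the limit cannot be read.

On these data alone, it remains open whether the number of compound 3 belongs to chloromethyl alone or would also appear with bromomethyl. As far as these compounds go, how an amine or a longer alkyl chain on this carbonyl carbon would read in this assay is also open.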